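A few compounds are considered here, and "the series" means these few. Any claim that something is new, unique, unknown or untested is made for them only; others in the source may bear on it.

The three measured compounds share one core and differ only in what sits on the amide-type nitrogen of the side chain. Compound 1 `NC(=O)Cn1c(-c2ccc(Cl)cc2)nc2cccnc21` carries an unsubstituted amide; in a functional assay on the whole organism with Mus musculus as the target (a lower number here means that less compound is needed, a higher number that more compound is needed for the effect), compound 1 gives 4.1 mg/kg. Compound 2 `CNC(=O)Cn1c(-c2ccc(Cl)cc2)nc2cccnc21` has methyl in place of hydrogen on an amide-type nitrogen, and in this assay compound 2 gives 12.5 mg/kg, so that a 3.0-fold higher number from compound 1 to compound 2 (0.48 log units; beyond the scatter). Compound 3 `CN(C)CCNC(=O)Cn1c(-c2ccc(Cl)cc2)nc2cccnc21` has 2-(dimethylamino)ethyl in place of hydrogen on an amide-type nitrogen; in this assay compound 3 gives 62 mg/kg, and a 15-fold higher number from compound 1 to compound 3 (1.18 log units; beyond the scatter).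

Compound 4 `CN(C)CCN(C)C(=O)Cn1c(-c2ccc(Cl)cc2)nc2cccnc21` has not yet been measured. It differs from compound 3 by methyl in place of hydrogen on an amide-type nitrogen. This is the same kind of change as that from compound 1 to compound 2, though the place is not identical: in compound 1 the other neighbour of that nitrogen is a carbonyl carbon only, while in compound 3 the other neighbours are a carbonyl carbon and a saturated chain carbon. Since a 3.0-fold higher number from compound 1 to compound 2 (0.48 log units; beyond the scatter) raised the number modestly, a step of roughly similar direction and size is expected for compound 4, namely a 2.3-fold higher number from compound 3 to compound 4 (0.35 log units; beyond the scatter). Compound 4 is therefore estimated to need about 140 mg/kg, most likely between 60 mg/kg and 350 mg/kg.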

Compound 4, dose for half-maximal effect: 100 mg/kg
Compound 4: middle estimate off by 1.4-fold (0.15 log units), on the high side; measured number inside the range.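

In this assay, methyl in place of hydrogen on the amide-type nitrogen gives a 1.6-fold higher number from compound 3 to compound 4 (0.21 log units; within the scatter), which alone does not establish a real change, and this step does not differ measurably from the earlier one: the same change on two cores in this assay, a 3.0-fold higher number (0.48 log units; beyond the scatter) from compound 1 to compound 2 and a 1.6-fold higher number (0.21 log units; within the scatter) from compound 3 to compound 4, 1.9-fold (0.28 log units) apart, within the scatter of two such steps. The 2-(dimethylamino)ethyl change gives an 8.0-fold higher number from compound 2 to compound 4 (0.90 log units; beyond the scatter), both changes made together give a 24-fold higher number from compound 1 to compound 4 (1.39 log units; beyond the scatter), and the 2-(dimethylamino)ethyl step also keeps its size from one core to the other: the same change on two cores in this assay, a 15-fold higher number (1.18 log units; beyond the scatter) from compound 1 to compound 3 and an 8.0-fold higher number (0.90 log units; beyond the scatter) from compound 2 to compound 4, 1.9-fold (0.28 log units) apart, within the scatter of two such steps. So in these two pairs each change carried over within the scatter, but two pairs in a single assay do not show that the same sizes would hold on any other core.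

The compounds shown leave open how other groups on that nitrogen, such as ethyl or a longer chain ending in the same dimethylamino group, would compare. They also leave open what a carboxylic acid or a morpholine in place of the dimethylamino group would do to the dose needed.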